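From Compound 1 to Compound 4: Extending the Chain

The source may hold more compounds than are shown below. What is called first, only, known or untested is meant among the compounds shown, and "the series" means these compounds.

Compound 1 `COCCCCCCCCCCC/C=C1\CC(CO)(COC(=O)C(C)(C)C)OC1=O` sits at the edge of the measurable range. In a functional assay on NCI-H322 cells (Homo sapiens) for antiproliferative activity (on this read-out lower numbers stand for stronger inhibition of growth and higher numbers for weaker inhibition of growth), compound 1 gives > 10 ug/mL, which is a limit of the assay and not a number. Compound 2 `CCCCCCCCC(O)CCCCCC/C=C1\CC(CO)(COC(=O)C(C)(C)C)OC1=O` gives > 10 ug/mL, also only a limit. Compound 3 `CC(C)(C)C(=O)OCC1(CO)C/C(=C/CCCCCCCCCCCCCCC=O)C(=O)O1` gives > 10 ug/mL, again only a limit. The whole set therefore rests on (the limit of > 10 ug/mL in this assay, at which 3 of the 3 values shown sit).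

Compound 4 `CC(C)(C)C(=O)OCCCCCCCCCCCCCCC/C=C1\CC(CO)(COC(=O)C(C)(C)C)OC1=O` departs from compound 1 by this change: 4-(((tert-butyl)carbonyl)oxy)butyl in place of methoxy on a saturated chain carbon, ten or more bonds along the chain from a double-bonded chain carbon. For the measured compounds named here, only one measured step bears on this, a step that the two limits leave unreadable from compound 1 to compound 2, and its size cannot be read, so it offers no measure and no direction. Going by the values given here, no compound here has yet given a number in this assay. The expected result is a step that the limit leaves unreadable from compound 1 to compound 4, with no shift beyond the scatter anticipated in either direction. The estimate for compound 4 is 15 ug/mL, with an expected range of 6 ug/mL to 40 ug/mL.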

Compound 4, concentration for 50% growth inhibition: > 10 ug/mL
Compound 4: no number, only a limit (the forecaster's own chance of this, stated with the estimate: 75%); the middle value lies beyond the limit too.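

Compound 4 gives > 10 ug/mL, which is a limit of the assay and not a number. For the compounds shown here, compound 1 also stands only at a limit, so no step from compound 1 to compound 4 can be read. The compounds shown leave open how far any of these chain changes moves growth inhibition in this assay, and in which direction: the limit of > 10 ug/mL in this assay, at which 4 of the 4 values shown sit.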